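Swapping One Aryl Group: What to Expect for Compound 3

The source may hold more compounds than are shown below. What is called first, only, known or untested is meant among the compounds shown, and "the series" means these compounds.

In a functional assay on L1210 cells (Mus musculus) for cytotoxicity, read by MTT assay (on this read-out higher numbers stand for weaker inhibition and lower numbers for stronger inhibition), compound 1 `O=C(N/N=C/c1ccc(F)cc1)c1cn(C2CC2)c2cc(N3CCNCC3)c(F)cc2c1=O` gives 25000 nM and compound 2 `COc1ccc(/C=N/NC(=O)c2cn(C3CC3)c3cc(N4CCNCC4)c(F)cc3c2=O)cc1O` gives 25000 nM, so compound 2 stands level with compound 1. Compound 3 `O=C(N/N=C/c1ccc([N+](=O)[O-])cc1)c1cn(C2CC2)c2cc(N3CCNCC3)c(F)cc2c1=O` keeps the shared core but carries 4-nitrophenyl in place of 3-hydroxy-4-methoxyphenyl on a carbon with a double bond to nitrogen. Among the compounds with values here, only one measured step bears on this place, and it shows no change at the digits printed from compound 1 to compound 2 (within the scatter). That single step gives no reason to expect a shift beyond the scatter, so the expected step in this assay is no change at the digits printed from compound 2 to compound 3 (within the scatter). The estimated value for compound 3 is 25000 nM, within a range of 10000 nM to 50000 nM.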

Compound 3, half-maximal inhibitory concentration: 25000 nM
The estimate for compound 3 equals the measured number at the digits printed; the range from low to high includes it.
By their numbers in this assay, from the lowest: compounds 1, 2 and 3 (each within the scatter of the next).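

In this assay, 4-nitrophenyl in place of 3-hydroxy-4-methoxyphenyl gives no change at the digits printed from compound 2 to compound 3 (within the scatter), and nitro in place of fluoro on an aromatic carbon gives no change at the digits printed from compound 1 to compound 3 (within the scatter). Three different aryl groups on this carbon with a double bond to nitrogen now read alike, so the flat result is no longer a single pairing of two groups. No available evidence accounts for this sameness. As far as these compounds go, whether a phenyl ring carrying an amine or a carboxylic acid would read differently remains open. So does whether a longer alkyl chain in place of the aryl ring would shift the number.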